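Bromo Added to the Trifluoromethyl Analogue: Expected Cytotoxicity

The source may hold more compounds than are shown below. What is called first, only, known or untested is meant among the compounds shown, and "the series" means these compounds.

Compound 3, `C=C1C[C@]23C[C@@]1(O)CC[C@H]2c1ccc(O)c(C)c1[C@@H]3Cn1cc(-c2ccc(C(F)(F)F)cc2)nn1`, carries a trifluoromethyl-substituted phenyl on its triazole and has no bromo on the shared core. In a functional assay on SMMC-7721 cells (Homo sapiens) for cytotoxicity, read by MTT assay, with a stated time of 4 days (on this read-out higher numbers stand for weaker inhibition and lower numbers for stronger inhibition), compound 3 gives > 20000 nM, which is a limit of the assay and not a number. Compound 3 thus stands at the limit, with no number to place it among the others, and the limit of > 20000 nM in this assay, at which 2 of the 3 values shown sit, shows that it does not sit there alone.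

Compound 4, `C=C1C[C@]23C[C@@]1(O)CC[C@H]2c1cc(Br)c(O)c(C)c1[C@@H]3Cn1cc(-c2ccc(C(F)(F)F)cc2)nn1`, differs from compound 3 by bromo in place of hydrogen on an aromatic carbon.

The measured compounds that already carry the bromo are compound 1, `C=C1C[C@]23C[C@@]1(O)CC[C@H]2c1cc(Br)c(O)c(C)c1[C@@H]3Cn1cc(-c2ccccc2)nn1`, and compound 2, `C=C1C[C@]23C[C@@]1(O)CC[C@H]2c1cc(Br)c(O)c(C)c1[C@@H]3Cn1cc(-c2ccc(Cl)cc2)nn1`. In this assay compound 1 gives > 20000 nM, a limit of the assay. In this assay compound 2 gives 19100 nM. Within the data shown here, the single measured step, an at least 1.0-fold lower number from compound 1 to compound 2 (0.01 log units; that floor lies within the scatter), lies within the scatter. Among the measured compounds shown here, no measured step adds a bromo itself; what the numbers show is that both bromo-bearing compounds sit at or very near the limit, just as compound 3 does without it. The step from compound 3 to compound 4 is therefore expected to be a number no higher from compound 3 to compound 4 (the limit leaves the size open), nothing beyond the scatter. Compound 4 is expected to give about 20000 nM, between 10000 nM and 40000 nM, with a good chance that this assay again reports only a limit.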

Compound 4, half-maximal inhibitory concentration: 12800 nM
For compound 4 the middle estimate is 1.6-fold (0.19 log units) above the measured one; low and high end bracket the measured number.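

With the bromo ortho to a hydroxy group, the trifluoromethyl analogue now yields a number and not a limit in this assay, yet the pair shows only an at least 1.5-fold lower number from compound 3 to compound 4 (0.19 log units; that floor lies within the scatter). Among the bromo-bearing compounds, trifluoromethyl in place of chloro gives a 1.5-fold lower number from compound 2 to compound 4 (0.17 log units; within the scatter), and trifluoromethyl in place of hydrogen gives an at least 1.5-fold lower number from compound 1 to compound 4 (0.19 log units; that floor lies within the scatter), so with the bromo in place, neither replacement on the phenyl separates from the scatter. Two of these three steps rest on a limit of the assay and not on a number, which leaves each of them a floor with its full size unknown: the limit of > 20000 nM in this assay, at which 2 of the 4 values shown sit.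

The compounds shown compare only hydrogen and bromo on this aromatic carbon, and they leave open whether any other group there, such as an amine or a hydroxy group, would move the number beyond the scatter. They also leave open how a carboxylic acid or a longer chain in place of the trifluoromethyl would read in this assay.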